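A few compounds are considered here, and "the series" means these few. Any claim that something is new, unique, unknown or untested is made for them only; others in the source may bear on it.

The measured compounds:

Compound 1, `CCOC(=O)C(=O)Nc1nc(-c2cccc(O)c2)cs1`. In a functional assay on the whole organism with Rattus norvegicus as the target (a higher number here means that more compound is needed for the effect, a lower number that less compound is needed), compound 1 gives > 10 mg/kg, which is a limit of the assay rather than a number.
Compound 2, `CCOC(=O)C(=O)Nc1nc(-c2ccc(O)c(O)c2)cs1`. In this assay compound 2 gives 1.4 mg/kg.
Compound 3, `CCOC(=O)C(=O)Nc1nc(-c2cc(OC)cc(OC)c2)cs1`. In this assay compound 3 gives about 10 mg/kg.

Compound 1 and compound 2 differ in one place: hydroxy in place of hydrogen on an aromatic carbon. That change brought an at least 7.1-fold lower number from compound 1 to compound 2 (0.85 log units; beyond the scatter). Since the value of compound 1 is only a limit, the true size of that step is not known; only its lower bound is, as shown by the limit of > 10 mg/kg in this assay, at which 1 of the 3 values shown sits.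

Compound 4, `CCOC(=O)C(=O)Nc1nc(-c2cc(OC)c(O)c(OC)c2)cs1`, has not been measured in this assay. It relates to compound 3 as compound 2 relates to compound 1: hydroxy in place of hydrogen on an aromatic carbon. How the core of compound 3 differs from the core of compound 1 is not broken down here. The surroundings of the new group are also not identical: in compound 2 the hydroxy sits ortho to a hydroxy group, in compound 4 it sits ortho to two methoxy groups, so this is the same kind of change rather than the same change.

With that in mind, the step from compound 3 to compound 4 is expected to be a 5.0-fold lower number from compound 3 to compound 4 (0.70 log units; beyond the scatter), resting on the step from compound 1 to compound 2, an at least 7.1-fold lower number from compound 1 to compound 2 (0.85 log units; beyond the scatter), which only a lower bound is known for. Compound 4 is therefore estimated to give 2 mg/kg in this assay, with a likely range from 0.7 mg/kg to 6 mg/kg.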

Compound 4, dose for half-maximal effect: about 10 mg/kg
Estimate against measurement, compound 4: 5.0-fold (0.70 log units) below, and the stated range ends below it.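

In this assay, adding a hydroxy group to the aromatic ring does not carry over from one core to the other in this series: it now brings no change at the digits printed from compound 3 to compound 4 (within the scatter), and the two steps differ by more than repeated measurements would explain: the same change on two cores in this assay, an at least 7.1-fold lower number (0.85 log units; beyond the scatter) from compound 1 to compound 2 and no change at the digits printed (within the scatter) from compound 3 to compound 4, at least 7.1-fold (0.85 log units) apart, beyond the scatter of two such steps

The full size of the earlier step remains unknown, as compound 1 sits at a limit of the assay and not at a number: the limit of > 10 mg/kg in this assay, at which 1 of the 4 values shown sits.

Among the compounds shown here, what the result does not show is why the steps part, or how general this is: with only one pair on each core, the difference between the cores cannot be separated from the surroundings of the new group, which in compound 4 sits ortho to two methoxy groups that compound 2 does not have.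

The compounds shown leave open how the same change would behave on other cores, and whether an amine in place of the new hydroxy on the core of compound 3 would behave any differently. They also leave open whether the change would hold up with a carboxylic acid in place of the ethyl ester, which is the same in all four compounds.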